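A New Side Chain on Compound 1

The compounds below may be only part of what the source reports. "The series", "measured", "known", "first", "only" and "open" are said of these compounds alone.

Compound 1 (`CCCCN(C)C(=O)CCCOc1cc(OC)c(OC)c2oc(-c3ccc(OC)cc3)c(O)c(=O)c12`) gives > 40000 nM in a functional assay on MCF7 cells (Homo sapiens) for antiproliferative activity, read by sulforhodamine B assay, with a stated time of 48 h (a higher number here means a weaker inhibitor, a lower number a stronger inhibitor), and this is a limit, not a number. Compound 2 (`COc1ccc(-c2oc3c(OC)c(OC)cc(OCCCCC(=O)N4CCN(C)CC4)c3c(=O)c2O)cc1`) gives > 40000 nM, also a limit. Compound 3 (`COc1ccc(-c2oc3c(OC)c(OC)cc(OCCCCCC(=O)NCc4ccccn4)c3c(=O)c2O)cc1`) gives > 40000 nM, again a limit. The whole record so far is therefore (the limit of > 40000 nM in this assay, at which 3 of the 3 values shown sit).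

Compound 4 (`COc1ccc(-c2oc3c(OC)c(OC)cc(OC(C)CN(C)C)c3c(=O)c2O)cc1`) keeps the core of compound 1 but carries 1-((dimethylamino)methyl)ethyl in place of 3-(butyl(methyl)carbamoyl)propyl on an oxygen on an aromatic ring.

Two measured changes to the side chain bear on this: a step that the two limits leave unreadable from compound 1 to compound 2 and a step that the two limits leave unreadable from compound 1 to compound 3. Neither offers a size to carry over. On those steps from compound 1, no large step is expected in this assay, at most a small move towards stronger inhibition, and a further limit is quite likely. In numbers, the expected change is an at least 1.3-fold lower number from compound 1 to compound 4 (0.12 log units; that floor lies within the scatter). The estimate for compound 4 is 30000 nM, with an expected range from 10000 nM to 60000 nM.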

Compound 4, half-maximal inhibitory concentration: 7200 nM
Estimate against measurement, compound 4: 4.2-fold (0.62 log units) above; measured number below the stated range.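

For the compounds shown here, compound 4 is the first compound here to give a readable number in this assay, and 1-((dimethylamino)methyl)ethyl in place of 3-(butyl(methyl)carbamoyl)propyl gives an at least 5.5-fold lower number from compound 1 to compound 4 (0.74 log units; beyond the scatter) and so a stronger inhibitor. This shows that a change on this oxygen on an aromatic ring can move the shared core off the assay limit, here with a dimethylamino group and no carbamoyl group in the side chain. The steps among compounds 1, 2 and 3 cannot be read, since their values give no sizes: the limit of > 40000 nM in this assay, at which 3 of the 4 values shown sit.

This single change shortens the side chain, adds a branch and replaces the carbamoyl group with an amine, so the compounds shown do not separate these features. An unbranched chain ending in dimethylamino, or a pyrrolidine in its place, would start to do so.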